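The source may hold more compounds than are shown below. What is called first, only, known or untested is meant among the compounds shown, and "the series" means these compounds.

Measured so far:
Compound 1 `O=S(=O)(/C=C/c1ccc(O)c(O)c1)CC1CCCCC1` gives 7500 nM in a functional assay, read by fluorescence and spectrophotometry, with a stated time of 1 h; a higher number here means that more compound is needed for the effect, a lower number that less compound is needed.
Compound 2 `O=S(=O)(/C=C/c1ccc(O)c(O)c1)CCCC1CCCCC1` gives 7900 nM in this assay.

Compound 2 and compound 1 sit within the usual scatter of each other, so neither stands apart on these numbers. Compound 3 `O=S(=O)(/C=C/c1ccc(O)c(O)c1)CCCCCCCO` differs from compound 2 by 4-hydroxybutyl in place of cyclohexyl on a saturated chain carbon, three bonds along the chain from a sulfonyl sulfur. For the measured compounds named here, no measured pair shows this kind of change, so the expected step in this assay is small and uncertain, leaning toward a slightly higher number. Compound 3 is estimated at 10000 nM, with a likely range from 3500 nM to 30000 nM. That estimate means an expected step of a 1.3-fold higher number from compound 2 to compound 3 (0.10 log units; within the scatter).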

Compound 3, half-maximal effective concentration: 5900 nM
For compound 3 the middle estimate is 1.7-fold (0.23 log units) above the measured one; measured number inside the range.
By their numbers in this assay, from the lowest: compounds 3, 1 and 2 (each within the scatter of the next).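

In this assay, 4-hydroxybutyl in place of cyclohexyl gives a 1.3-fold lower number from compound 2 to compound 3 (0.13 log units; within the scatter) and 6-hydroxyhexyl in place of cyclohexyl gives a 1.3-fold lower number from compound 1 to compound 3 (0.10 log units; within the scatter) at the two chain positions involved. So, on these compounds, cyclohexyl can give way to an open chain ending in a hydroxyl group without the number leaving the scatter. Nothing available explains why these numbers stay so close. Ring and hydroxyl change together in these steps. A plain hexyl chain would be needed to separate them. On these data alone, whether an amine or a carboxylic acid at the chain end would shift the number remains open.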